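This account rests on a few compounds, and the source may have more. Where it says the series, first, only, none or still open, it means among the compounds named here.

Measured compounds in an assay on CV-1 cells for activation of retinoic acid receptor beta (Homo sapiens); on this read-out higher numbers stand for an effect only at larger amounts of compound and lower numbers for an effect already at smaller amounts:
compound 1 `C/C(=C\c1ccc(C(=O)O)cc1)c1ccc2c(c1)C(C)(C)CCO2` gives 190 nM;
compound 2 `C/C(=C\c1ccc(C(=O)O)cc1)c1ccc2c(c1)C(C)(C)CO2` gives 320 nM;
compound 3 `COC(=O)c1ccc(/C=C(\C)c2ccc3c(c2)C(C)(C)CCO3)cc1` gives 140 nM.

Compounds 1 and 3 share one core and differ by a single change, (methyl in place of hydrogen on an oxygen next to a carbonyl group). The step of a 1.4-fold lower number from compound 1 to compound 3 (0.13 log units; within the scatter) is small. Compound 2 rests on a different core from compound 1; how the two cores differ is not broken down here. Compound 4 `COC(=O)c1ccc(/C=C(\C)c2ccc3c(c2)C(C)(C)CO3)cc1` has not been measured. It stands to compound 2 as compound 3 stands to compound 1, carrying the same change at the same place, (methyl in place of hydrogen on an oxygen next to a carbonyl group). A step of similar size is expected, a 1.3-fold lower number from compound 2 to compound 4 (0.12 log units; within the scatter), because the earlier step of a 1.4-fold lower number from compound 1 to compound 3 (0.13 log units; within the scatter) stayed within the scatter, though this rests on one prior example only. Compound 4 is therefore estimated at 240 nM, most likely between 110 nM and 520 nM.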

Compound 4, half-maximal effective concentration: 430 nM
Compound 4: middle estimate off by 1.8-fold (0.25 log units), on the low side, within the range that was stated.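

Changing carboxy to methoxycarbonyl on the core of compound 2 gives a 1.3-fold higher number from compound 2 to compound 4 (0.13 log units; within the scatter) in this assay. Set beside the same change on the core of compound 1, this step does not differ from the earlier one by more than repeated measurements would: the same change on two cores in this assay, a 1.4-fold lower number (0.13 log units; within the scatter) from compound 1 to compound 3 and a 1.3-fold higher number (0.13 log units; within the scatter) from compound 2 to compound 4, 1.8-fold (0.26 log units) apart, within the scatter of two such steps. In these two pairs, then, the change carries from one core to the other without a clear effect on either, but two pairs cannot show that this holds on a further core, and the opposite signs of the two steps carry no meaning.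

The compounds shown leave open whether an ethyl ester or an amide in place of the carboxylic acid would behave the same way.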